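The source may hold more compounds than are shown below. What is called first, only, known or untested is meant among the compounds shown, and "the series" means these compounds.

Working notes on the series.

Compound 1, `CC(C)c1nnc(-c2ccc(N3CCC(Oc4ccccc4C(F)(F)F)CC3)nn2)s1`, gives 8.8 nM in an assay on microsomes from liver for inhibition of acyl-CoA desaturase 1 (Rattus norvegicus); on this read-out lower numbers stand for stronger inhibition and higher numbers for weaker inhibition. Compound 2, `c1cn(-c2ccc(N3CCC(Oc4ccc5c(c4)CCC5)CC3)nn2)cn1`, gives 62 nM in this assay. Within the data shown here, of the numbers measured so far, compound 1 stands lowest; the gap to compound 2 is beyond the scatter, so compound 1 is the stronger inhibitor of the pair. The two compounds differ at several positions at once, so no single change can be read from that gap.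

Compound 3, `CC(C)(C)c1nnc(-c2ccc(N3CCC(Oc4ccccc4C(F)(F)F)CC3)nn2)s1`, is not yet measured. It differs from compound 1 in one place: methyl in place of hydrogen on a saturated chain carbon bound to an aromatic carbon and two saturated chain carbons.

Among the measured compounds shown here, no step between measured compounds isolates this change, so there is nothing in the set from which its size can be read. The change is small, adds no donor or acceptor and leaves the rest of the structure of compound 1 untouched. The expectation is that the step of a 1.0-fold higher number from compound 1 to compound 3 (0.01 log units; within the scatter) stays within the scatter, in either direction, with the number of compound 1 as the anchor.

Compound 3 is therefore estimated at 9 nM in this assay, expected between 3 nM and 30 nM.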

Compound 3, half-maximal inhibitory concentration: 710 nM
The estimate for compound 3 lay 79-fold (1.90 log units) below the measured number; the measured number lies above the stated range.
By their numbers in this assay, from the lowest: compound 1; then compound 2; then compound 3.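

Among these compounds, the isopropyl to tert-butyl change on the 1,3,4-thiadiazol-2-yl group is the first single change that can be read, and in this assay it gives an 81-fold higher number from compound 1 to compound 3 (1.91 log units; beyond the scatter). This shows that the saturated chain carbon bound to an aromatic carbon and two saturated chain carbons is not a neutral place for substitution: replacing one hydrogen with methyl, which enters no hydrogen-bond donor or acceptor, is enough to weaken inhibition far beyond the scatter. Nothing available on this pair bears on the reason for a step of this size.

With only isopropyl and tert-butyl read at this place, the compounds shown leave open how an ethyl, a cyclopropyl or a methoxymethyl group would stand, and whether a hydroxyl or an amine on that same chain carbon would keep the number of compound 1 or follow compound 3. They also leave open whether the step holds with other groups on the far end of the molecule, since this single pair carries only the 2-(trifluoromethyl)phenyl ether.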